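The compounds below may be only part of what the source reports. "The series", "measured", "known", "first", "only" and "open" are said of these compounds alone.

Compound 1, `Fc1ccccc1NC(=S)Nc1cccc(C(F)(F)F)c1`, gives > 100000 nM in an ADME assay on MDBK cells (Bos taurus) for cytotoxicity, read by MTT assay, with a stated time of 96 h; a higher number here means that more compound is tolerated, a lower number that less compound is tolerated.
Compound 2, `COc1cccc(NC(=S)Nc2cccc(C(F)(F)F)c2)c1`, gives 52000 nM in this assay.
Compound 3, `CCCCc1ccc(NC(=S)Nc2cccc(C(F)(F)F)c2)c(C)c1`, gives 10000 nM in this assay.

For compound 1 the value is a limit of the assay rather than a number, (the limit of > 100000 nM in this assay, at which 1 of the 3 values shown sits). Compound 2 and compound 3 gave measured numbers, with compound 3 tolerated the least of the three. Compound 4, `CC(=O)NC(=S)Nc1cccc(C(F)(F)F)c1`, has not yet been measured. It differs from compound 1 in one place: acetyl in place of 2-fluorophenyl on an amide-type nitrogen. Among the compounds with values here, no step between two measured compounds is available to guide this change, so the expectation for compound 4 rests on compound 1 alone. The step from compound 1 to compound 4 is expected to be a number no higher from compound 1 to compound 4 (the limit leaves the size open), within the scatter. Compound 4 is estimated at 100000 nM, in the range from 30000 nM to 300000 nM.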

Compound 4, half-maximal cytotoxic concentration: > 100000 nM
Compound 4 gave a limit, no number; the forecaster's own chance of this, stated with the estimate: 60%; the middle value lies on the limit itself.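

Compound 1 and compound 4 both give a limit of the assay rather than a number, so no step can be read between them: the limit of > 100000 nM in this assay, at which 2 of the 4 values shown sit.

As far as these compounds go, whether acetyl and 2-fluorophenyl on that amide-type nitrogen differ at all in this assay remains open.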